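Solubility notes on a shared-core series

This account rests on a few compounds, and the source may have more. Where it says the series, first, only, none or still open, it means among the compounds named here.

In an ADME assay for solubility (on this read-out lower numbers stand for lower solubility and higher numbers for higher solubility), the measured compounds stand as follows:
compound 1 `CCCCCCCCCCCCCCCCCCSCC(COP(=O)(O)OP(=O)(O)OC[C@H]1OC(n2ccc(N)nc2=O)[C@@H](O)[C@@H]1O)OC(=O)CCCCCCCCCCCCCCC` gives 200000 nM
compound 2 `CCCCCCCCCCCCCCCC(=O)OC(COP(=O)(O)OP(=O)(O)OC[C@H]1OC(n2ccc(N)nc2=O)[C@@H](O)[C@@H]1O)CSCCCCCCCCCCCCCC` gives 1500000 nM
compound 3 `CCCCCCCCCCCCCCCCSCC(COP(=O)(O)OP(=O)(O)OC[C@H]1OC(n2ccc(N)nc2=O)[C@@H](O)[C@@H]1O)OC(=O)CCCCCCCCCCCCC` gives > 53000000 nM, which is a limit of the assay and not a number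

From compound 2 to compound 1 the change is butyl in place of hydrogen on a saturated chain carbon, ten or more bonds along the chain from a sulfur, and in this assay it made a 7.5-fold lower number from compound 2 to compound 1 (0.88 log units; beyond the scatter). Compound 3 has the same atoms as compound 2 joined differently; the difference between the two cores is not broken down here.

Compound 4 `CCCCCCCCCCCCCCCCCC(=O)OC(COP(=O)(O)OP(=O)(O)OC[C@H]1OC(n2ccc(N)nc2=O)[C@@H](O)[C@@H]1O)CSCCCCCCCCCCCCCCCC` is not yet measured. From compound 3 it carries butyl in place of hydrogen on a saturated chain carbon, ten or more bonds along the chain from a carbonyl carbon, the same kind of change as from compound 2 to compound 1, but here the place is along the chain from a carbonyl carbon rather than from a sulfur. For compound 3 only the limit of > 53000000 nM in this assay, at which 1 of the 3 values shown sits, is known, so the starting point is open.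

By analogy to a 7.5-fold lower number from compound 2 to compound 1 (0.88 log units; beyond the scatter), a step of about an at least 5.3-fold lower number from compound 3 to compound 4 (0.72 log units; beyond the scatter) is expected in this assay, with the wide uncertainty of an unknown start. Compound 4 is estimated at 10000000 nM, between 1000000 nM and 100000000 nM.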

Compound 4, solubility: 200000 nM
Compound 4: the middle estimate sits 50-fold (1.70 log units) above what was measured; measured number below the stated range.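

In this assay butyl in place of hydrogen gave an at least 260-fold lower number from compound 3 to compound 4 (2.42 log units; beyond the scatter). Set beside the earlier step, the direction carries from one core to the other but the size does not: the same change on two cores in this assay, a 7.5-fold lower number (0.88 log units; beyond the scatter) from compound 2 to compound 1 and an at least 260-fold lower number (2.42 log units; beyond the scatter) from compound 3 to compound 4, at least 35-fold (1.54 log units) apart, beyond the scatter of two such steps

Compound 3 gives > 53000000 nM, which is a limit of the assay and not a number, so these pairs do not show the full size of its step or why the two steps differ: the limit of > 53000000 nM in this assay, at which 1 of the 4 values shown sits.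

Two pairs cannot separate the effect of the core from that of the place on the chain, along the chain from a sulfur in one case and from a carbonyl carbon in the other. Going by these compounds, how a longer chain, or an amine on either chain, would behave on these cores stays open.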